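A Shorter Fluorinated Arm on the Shared Core

The source may hold more compounds than are shown below. What is called first, only, known or untested is meant among the compounds shown, and "the series" means these compounds.

The measured compounds:
compound 1, `Cc1nc(S(C)(=O)=O)ccc1Oc1ncnc(OC2CCN(C(=O)O[C@H](C)C(F)(F)F)CC2)c1F`, gives 110 nM
compound 2, `Cc1nc(S(C)(=O)=O)ccc1Oc1ncnc(OC2CCN(C(=O)O[C@@H](C)C(F)(F)F)CC2)c1F`, gives 109 nM
compound 3, `Cc1nc(S(C)(=O)=O)ccc1Oc1ncnc(OC2CCN(C(=O)OC3(C(F)(F)F)COC3)CC2)c1F`, gives 342 nM

All three were tested in a functional assay on isolated protein for inhibition of Glucose-dependent insulinotropic receptor (Rattus norvegicus), read by HTRF and cAMP accumulation; on this read-out lower numbers stand for an effect already at smaller amounts and higher numbers for an effect only at larger amounts of compound. Compound 1 stands second highest of the three numbers; its nearest neighbour is compound 2, and the step of a 1.0-fold lower number from compound 1 to compound 2 (0.00 log units; within the scatter) is within the scatter, which fits because of the fact that compounds 1 and 2 differ only in the configuration as drawn. The furthest is compound 3, reached by the step of a 3.1-fold higher number from compound 1 to compound 3 (0.49 log units; beyond the scatter), where 3-(trifluoromethyl)oxetan-3-yl replaces 1-(trifluoromethyl)ethyl on an oxygen next to a carbonyl group.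

The next compound, compound 4, `Cc1nc(S(C)(=O)=O)ccc1Oc1ncnc(OC2CCN(C(=O)C(C)(F)F)CC2)c1F`, changes the same region but in a different way: 1,1-difluoroethyl in place of 1-(trifluoromethyl)ethoxy on a carbonyl carbon. The oxygen that carried the varied group is gone, and the group that enters is smaller than either of those measured before.

The step from compound 1 to compound 3 is the only one that bears on this region, and it was modest. The step to compound 4 is a different kind of change, so its size cannot be read off directly, but a modest step toward a higher number is expected, a 2.4-fold higher number from compound 1 to compound 4 (0.37 log units; beyond the scatter). Compound 4 is therefore estimated at 260 nM, with a range from 80 nM to 850 nM.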

Compound 4, half-maximal effective concentration: 239 nM
Compound 4: the middle estimate sits 1.1-fold (0.04 log units) above what was measured, within the range that was stated.
By their numbers in this assay, from the lowest: compounds 2 and 1 (each within the scatter of the next); then compounds 4 and 3 (each within the scatter of the next).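

Replacing the carbonyl-bound 1-(trifluoromethyl)ethoxy with 1,1-difluoroethyl shows that this position tolerates losing the oxygen and the defined stereocentre at a modest cost, with a 2.2-fold higher number from compound 1 to compound 4 (0.34 log units; beyond the scatter) and an equally sized a 2.2-fold higher number from compound 2 to compound 4 (0.34 log units; beyond the scatter), so the starting configuration makes no difference to the outcome. Compound 3 had shown a modest rise with a different oxygen-linked group, whereas this smaller group without that oxygen lands level with it, as a 1.4-fold lower number from compound 3 to compound 4 (0.16 log units; within the scatter) stays within the scatter, and among these four compounds both departures from the 1-(trifluoromethyl)ethoxy carbamates end on the higher side. Nothing in the available evidence accounts for the size of these steps.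

The step to compound 4 changes the linking oxygen, the length of the arm and the number of fluorines at once, so the compounds shown do not separate what each of these contributes. Neither a plain ethyl group on the carbonyl carbon nor a 2,2-difluoropropoxy group appears among them, and either would help to tell the oxygen apart from the fluorines and the chain length.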